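Cytotoxicity notes on a biaryl amide acid series

The compounds below may be only part of what the source reports. "The series", "measured", "known", "first", "only" and "open" are said of these compounds alone.

Compound 1 `CC(C)N(Cc1cccc(OCCCCCC(=O)O)c1)C(=O)c1ccc(-c2cccc(OCc3ccccc3)c2)cc1`: in an ADME assay on BJ cells (Homo sapiens) for cytotoxicity, read by CellTiter-Glo and resazurin assay, with a stated time of 72 h (on this read-out higher numbers stand for an effect only at larger amounts of compound and lower numbers for an effect already at smaller amounts), compound 1 gives > 26000 nM, a limit of the assay.
Compound 2 `CC(C)N(Cc1cccc(OCCCCCC(=O)O)c1)C(=O)c1ccc(-c2cccc(OC(F)(F)F)c2)cc1`: in this assay compound 2 gives > 26000 nM, also a limit of the assay.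

Within the data shown here, compound 2 stands at the assay limit, and the only other measured value is a limit as well, so no number orders the two. The step from compound 1 to compound 2 reads a step that the two limits leave unreadable from compound 1 to compound 2, and its size cannot be read. The change to compound 3 `CC(C)N(Cc1cccc(OCCCCCC(=O)O)c1)C(=O)c1ccc(-c2cccc(Br)c2)cc1` is bromo in place of trifluoromethoxy on an aromatic carbon; cut one bond further out, it reads 3-(trifluoromethoxy)phenyl to 3-bromophenyl. Among the measured compounds shown here, no measured step is readable, and the limit of > 26000 nM in this assay, at which 2 of the 2 values shown sit, is the whole of the evidence. A step that the limit leaves unreadable from compound 2 to compound 3 is therefore expected. Compound 3 is estimated at 40000 nM, with a range of 20000 nM to 100000 nM, and will most likely again be reported as a limit.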

Compound 3, half-maximal effective concentration: > 26000 nM
Compound 3 gave a limit, no number; the forecaster's own chance of this, stated with the estimate: 85%; the middle value does not contradict the limit.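

Compound 1, compound 2 and compound 3 all sit at a limit of the assay rather than at a number, so no step among them can be read: the limit of > 26000 nM in this assay, at which 3 of the 3 values shown sit.

The compounds shown leave open whether benzyloxy, trifluoromethoxy and bromo differ at all in this read-out.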